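The compounds below may be only part of what the source reports. "The series", "measured", "known", "first", "only" and "open" are said of these compounds alone.

Working notes on the series. In an assay on microsomes from intestine for inhibition of acyl-CoA:cholesterol acyltransferase (Oryctolagus cuniculus) (on this read-out higher numbers stand for weaker inhibition and lower numbers for stronger inhibition), compound 1 `CCCCCCCC/C=C/CCCCCCCC(=O)Nc1ccc(OC)cc1OC` gives 3000 nM. For the measured compounds named here, compound 2 `CCCCCCCC/C=C/CCCCCCCC(=O)Nc1cc(C(=O)OC)c(OC)cc1OC` gives 1100 nM in this assay, the lowest of the two numbers so far; the only step measured is a 2.7-fold lower number from compound 1 to compound 2 (0.44 log units; beyond the scatter). Compound 3 `CCCCCCCC/C=C/CCCCCCCC(=O)Nc1cc(Cl)c(OC)cc1OC` differs from compound 2 by chloro in place of methoxycarbonyl on an aromatic carbon. Going by the values given here, the step from compound 1 to compound 2 bears on this only indirectly, since it compares hydrogen with methoxycarbonyl, not chloro with methoxycarbonyl; no measured step covers the present exchange. A step of a 1.4-fold higher number from compound 2 to compound 3 (0.13 log units; within the scatter) is therefore expected, with no direction beyond the scatter. Compound 3 is estimated at 1500 nM, range 500 nM to 5000 nM.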

Compound 3, half-maximal inhibitory concentration: 520 nM
For compound 3 the middle estimate is 2.9-fold (0.46 log units) above the measured one; the measured number falls inside the stated range.
By their numbers in this assay, from the lowest: compound 3; then compound 2; then compound 1.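

In this assay this aromatic carbon, ortho to a methoxy group and para to a methoxy group, tolerates more than one substituent: chloro in place of hydrogen gives a 5.8-fold lower number from compound 1 to compound 3 (0.76 log units; beyond the scatter) and chloro in place of methoxycarbonyl gives a 2.1-fold lower number from compound 2 to compound 3 (0.33 log units; beyond the scatter) in this series. The carbonyl and the four heavy atoms of methoxycarbonyl are therefore not required for the lower number here. Nothing available explains the difference between these groups. Open, going by these compounds, is whether fluoro, bromo, methyl or an amine at this carbon would follow chloro or methoxycarbonyl.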